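Adding a second methoxy group to the anilino-ketone pyrazole

The source may report more compounds than this note shows. Statements on the series, on what has been measured and on what is new or still open speak of the compounds shown alone.

Compound 1 `COc1ccc(-c2cc(/C=C/C(=O)c3ccc(N)cc3)[nH]n2)cc1` is the strongest of the three compounds measured in a functional assay on HCT-15 cells (Homo sapiens) for cytotoxicity, read by sulforhodamine B assay, with a stated time of 48 h, tested at 10 uM; on this read-out higher numbers stand for a weaker effect at the one concentration tested and lower numbers for a stronger effect: compound 1 gives -40%, the lowest number of the three. Compound 2 `COc1cc(-c2cc(/C=C/C(=O)c3ccc(Cl)c(Cl)c3)[nH]n2)cc(OC)c1OC` gives 29%, and compound 3 `COc1cc(-c2cc(/C=C/C(=O)c3ccc(F)c(F)c3)[nH]n2)cc(OC)c1OC` gives 9%; compound 1 stands below both by more than the scatter.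

For the measured compounds named here, the only single-point step among the measured compounds is a number 20 percentage points lower from compound 2 to compound 3 (beyond the scatter), which concerns the ring on the carbonyl carbon and not the ring that changes here. Compound 4 `COc1ccc(-c2cc(/C=C/C(=O)c3ccc(N)cc3)[nH]n2)cc1OC` differs from compound 1 as follows: methoxy in place of hydrogen on an aromatic carbon. Going by the values given here, compound 2 and compound 3 both carry three methoxy groups on that ring, but each also differs from compound 1 on the carbonyl side, so their values show only that such ring patterns can sit far above compound 1 without telling what the added methoxy group alone does.

Among the compounds with values here, no measured step therefore bears directly on this change. Compound 4 is expected to keep a strong effect, with a step of a number 15 percentage points higher from compound 1 to compound 4 (beyond the scatter) that may or may not exceed the scatter. Compound 4 is estimated at -25%, within a range from -65% to 15%.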

Compound 4, a percentage reported as activity, at one concentration (the size of the read-out at that concentration, not a potency): -27%
The estimate for compound 4 lay 2 percentage points above the measured number; low and high end bracket the measured number.
By their numbers in this assay, from the lowest: compound 1; then compound 4; then compound 3; then compound 2.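

For the compounds shown here, the step of a number 13 percentage points higher from compound 1 to compound 4 (beyond the scatter) in this assay is the first reading of the added methoxy group on its own, since compound 2 and compound 3 each change the carbonyl side as well as the methoxy pattern. It shows that the added methoxy group, ortho to a methoxy group and meta to a large group, gives a modest weakening that lies beyond the scatter, yet compound 4 keeps a number below zero, so the change does not remove the strong effect seen with compound 1. Nothing among the available data accounts for the size or direction of this step.

The compounds shown leave open whether a hydroxy or an ethoxy group on the same aromatic carbon would give a step of similar size, so it cannot yet be said whether the result is particular to methoxy. Going by these compounds alone, they also leave open what a third methoxy group would do on this ring while the amine on the carbonyl side stays in place, since only one added methoxy group has been read with that amine present.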